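The compounds below may be only part of what the source reports. "The series", "measured", "known", "first", "only" and "open" are said of these compounds alone.

The measured compounds are three: compound 1 `COc1cc(-c2cc(/C=C/C(=O)c3ccc(N)cc3)[nH]n2)cc(OC)c1OC`, which in a functional assay on RPMI-8226 cells (Homo sapiens) for cytotoxicity, read by sulforhodamine B assay, with a stated time of 48 h, tested at 1 uM (a lower number here means a stronger effect, a higher number a weaker effect of the compound at the concentration tested), gives 28%; compound 2 `COc1ccc(C(=O)/C=C/c2cc(-c3cc(OC)c(OC)c(OC)c3)n[nH]2)cc1OC`, which gives 2%; and compound 3 `COc1ccc(C(=O)/C=C/c2cc(-c3cc(OC)c(OC)c(OC)c3)n[nH]2)cc1`, which gives 27%.

Compound 3 stands second highest of the three numbers. Its nearest neighbour is compound 1, and the change between them, a number 1 percentage points lower from compound 1 to compound 3 (within the scatter), is within the scatter. Its furthest is compound 2, from which it is separated by a number 25 percentage points higher from compound 2 to compound 3 (beyond the scatter).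

Compound 4 `COc1cc(-c2cc(/C=C/C(=O)c3ccc(F)c(F)c3)[nH]n2)cc(OC)c1OC` is not yet measured. It differs from compound 3 as follows: 3,4-difluorophenyl in place of 4-methoxyphenyl on a carbonyl carbon.

For the measured compounds named here, only one measured step touches the same ring: the removal of a methoxy, a number 25 percentage points higher from compound 2 to compound 3 (beyond the scatter), a modest rise. Going by the values given here, no measured step introduces fluorine, so the effect of the entering group is unknown. Taking the loss of the methoxy as the nearer guide, the expected step is a number 13 percentage points higher from compound 3 to compound 4 (beyond the scatter), a small rise or none beyond the scatter. Compound 4 is therefore expected to give about 40%, estimated between 15% and 75%.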

Compound 4, a percentage reported as activity, at one concentration (the size of the read-out at that concentration, not a potency): 73%
Compound 4: the middle estimate sits 33 percentage points below what was measured; low and high end bracket the measured number.
By their numbers in this assay, from the lowest: compound 2; then compounds 3 and 1 (each within the scatter of the next); then compound 4.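

At the carbonyl carbon, the earlier changes gave modest steps at most, whereas 3,4-difluorophenyl gives large ones in this assay: a number 46 percentage points higher from compound 3 to compound 4 (beyond the scatter), a number 71 percentage points higher from compound 2 to compound 4 (beyond the scatter) and a number 45 percentage points higher from compound 1 to compound 4 (beyond the scatter). Compound 4 therefore shows the weakest effect of the set. Compound 2 and compound 4 differ only in 3,4-dimethoxyphenyl and 3,4-difluorophenyl, which stand at the two ends of the range, so what sits on the ring matters. The data shown offer no explanation for this large loss of effect.

As far as these compounds go, it remains open whether 4-fluorophenyl, with a single fluorine, or 3,4-dichlorophenyl would fall nearer to compound 2 or to compound 4. The same holds for an unsubstituted phenyl, and a single tested concentration shows only a stronger or weaker effect at that concentration.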